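Methyl in Place of Chloro: Estimating Compound 4

The source may hold more compounds than are shown below. What is called first, only, known or untested is meant among the compounds shown, and "the series" means these compounds.

Three compounds share one core and differ only in the group attached through oxygen. In an assay on isolated protein for inhibition of Amine oxidase [flavin-containing] B (Homo sapiens), read by fluorescence and spectrophotometry, with a stated time of 20 min (on this read-out higher numbers stand for weaker inhibition and lower numbers for stronger inhibition), compound 2 `O=C1CSc2cc(OCc3ccc(Cl)cc3)ccc2N1` gives 2.7 nM, the lowest of the three numbers: compound 1 `O=C1CSc2cc(OCc3ccccc3)ccc2N1` gives 71 nM, and compound 3 `CCCOc1ccc2c(c1)SCC(=O)N2` gives 2870 nM. The step from compound 1 to compound 2 was a 26-fold lower number from compound 1 to compound 2 (1.42 log units; beyond the scatter), while a 40-fold higher number from compound 1 to compound 3 (1.61 log units; beyond the scatter) marked the step from compound 1 to compound 3. Compound 4 `Cc1ccc(COc2ccc3c(c2)SCC(=O)N3)cc1` differs from compound 2 by methyl in place of chloro on an aromatic carbon. Among the compounds with values here, only the step from compound 1 to compound 2 bears on this change, and it shows that the group on that aromatic carbon matters strongly. A modest weakening in this assay is expected, a 3.0-fold higher number from compound 2 to compound 4 (0.47 log units; beyond the scatter). Compound 4 is estimated at 8 nM, with a range from 2 nM to 40 nM.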

Compound 4, half-maximal inhibitory concentration: 8.2 nM
Compound 4: the middle estimate sits 1.0-fold (0.01 log units) below what was measured; measured number inside the range.
By their numbers in this assay, from the lowest: compound 2; then compound 4; then compound 1; then compound 3.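

In this assay, hydrogen on this aromatic carbon can be replaced with benefit by more than chloro: methyl also lowers the number, with an 8.7-fold lower number from compound 1 to compound 4 (0.94 log units; beyond the scatter). The two replacements are still not equal, since the change from chloro to methyl gives a 3.0-fold higher number from compound 2 to compound 4 (0.48 log units; beyond the scatter), so most of the gain survives but part is lost. No measurement here gives a reason for either step. The compounds shown leave open how an amine or a methoxy group on this same carbon would read.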